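The source may report more compounds than this note shows. Statements on the series, on what has been measured and on what is new or still open speak of the compounds shown alone.

In a functional assay on MGC-803 cells (Homo sapiens) for antiproliferative activity, read by CCK-8 assay, with a stated time of 72 h (a higher number here means a weaker inhibitor, a lower number a stronger inhibitor), compound 2 `Nc1ccccc1NC(=O)/C=C/c1ccc(COc2ccccc2)cc1` gives > 32000 nM, which is a limit and not a number. Compound 1 `Nc1ccccc1NC(=O)c1ccc(COc2ccc(Br)cc2)cc1` gives > 32000 nM, which is also a limit. Together they make up (the limit of > 32000 nM in this assay, at which 2 of the 3 values shown sit). For the measured compounds named here, compound 3 `Nc1ccccc1NC(=O)c1ccc(COc2ccccc2)cc1` is the only one with a true number, at 5670 nM.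

Compound 4 `Nc1cnccc1NC(=O)/C=C/c1ccc(COc2ccccc2)cc1` keeps the rest of compound 2 and changes one group: 3-aminopyridin-4-yl in place of 2-aminophenyl on an amide-type nitrogen. In words, 3-aminopyridin-4-yl replaces 2-aminophenyl on the amide-type nitrogen.

Going by the values given here, no measured step makes this exact swap. The closest guide is an at least 5.6-fold lower number from compound 1 to compound 3 (0.75 log units; beyond the scatter), where hydrogen replaces bromo on an aromatic carbon. That step shows that a single small change can take compound 3 clear of the limit reached by compound 1, but it involves a different group and so sets no firm size here. A modest move toward a lower number is therefore expected, although a result at the limit would be no surprise.

The expected change is an at least 2.2-fold lower number from compound 2 to compound 4 (0.35 log units; beyond the scatter). For compound 4, the estimated value is 14000 nM, with an expected range from 2500 nM to 32000 nM.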

Compound 4, half-maximal inhibitory concentration: > 32000 nM
Compound 4 was reported as a limit; the forecaster's own chance of this, stated with the estimate: 45%; middle value at least 2.2-fold (0.35 log units) from the limit.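

In this assay, compound 2 and compound 4 both stop at a limit and not at a true number, so no step between them can be read: the limit of > 32000 nM in this assay, at which 3 of the 4 values shown sit.

Left open is whether 3-aminopyridin-4-yl in place of 2-aminophenyl on the amide-type nitrogen changes activity at all, and in which direction.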